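The compounds below may be only part of what the source reports. "The series", "measured", "known", "first", "only" and "open" are said of these compounds alone.

- Compound 1 `COc1cc(/C=C/c2ccc(OCCCC(=O)NO)cc2)cc(OC)c1`: 3890 nM
- Compound 2 `COc1cc(/C=C/c2ccc(OCc3ccccc3C(=O)NO)cc2)cc(OC)c1`: 7180 nM

In a functional assay on MDA-MB-231 cells (Homo sapiens) for cytotoxicity, read by MTT assay, with a stated time of 48 h (a lower number here means a stronger inhibitor, a higher number a weaker inhibitor), compound 2 at 7180 nM lies within the usual scatter of compound 1. Compound 3 `COc1cc(/C=C/c2ccc(OCc3ccc(C(=O)NO)cc3)cc2)cc(OC)c1` differs from compound 2 only in where the hydroxycarbamoyl group sits on the phenyl ring: 4-(hydroxycarbamoyl)phenyl in place of 2-(hydroxycarbamoyl)phenyl on a saturated chain carbon bound to an oxygen on an aromatic ring. Among the measured compounds shown here, only one measured step bears on this, a 1.8-fold higher number from compound 1 to compound 2 (0.27 log units; within the scatter). It exchanged a different group at the same place and stayed within the scatter, though it does not test this ring change directly. The expected change is therefore no more than a 1.3-fold lower number from compound 2 to compound 3 (0.12 log units; within the scatter), nothing beyond the scatter. For compound 3 the estimate is 5500 nM, with an expected range of 2000 nM to 15000 nM.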

Compound 3, half-maximal inhibitory concentration: 6880 nM
For compound 3 the middle estimate is 1.3-fold (0.10 log units) below the measured one, within the range that was stated.
By their numbers in this assay, from the lowest: compounds 1, 3 and 2 (each within the scatter of the next).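

In this assay, the hydroxycarbamoyl group now moves on the phenyl ring itself, and this direct test gives a 1.0-fold lower number from compound 2 to compound 3 (0.02 log units; within the scatter). Placing 4-(hydroxycarbamoyl)phenyl at the site of the 2-(hydroxycarbamoyl)ethyl group gives a 1.8-fold higher number from compound 1 to compound 3 (0.25 log units; within the scatter), so neither ring placement stands apart from the chain in these three compounds. No measurement here explains this lack of separation. Still open, going by these compounds, is whether the same holds for a longer chain at this place. Whether a carboxylic acid in place of the hydroxycarbamoyl group would change the number also remains unanswered.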